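The source may report more compounds than this note shows. Statements on the series, on what has been measured and on what is new or still open speak of the compounds shown alone.

Compound 1, `CCCN1CCN(c2ccc(S(=O)(=O)Oc3ccccc3C)cc2)C1=O`, gives > 100000 nM in a functional assay on MCF7 cells (Homo sapiens) for antiproliferative activity, read by sulforhodamine B assay, with a stated time of 48 h; a higher number here means a weaker inhibitor, a lower number a stronger inhibitor.
Compound 2, `CCCN1CCN(c2ccc(S(=O)(=O)Oc3cc(Cl)c(Cl)cc3Cl)cc2)C1=O`, gives 13000 nM in this assay.

The value for compound 1 is a limit of the assay, not a number. Within the data shown here, compound 2 therefore holds the only number in this set, the other value being a limit. Among the measured compounds shown here, the one measured step runs an at least 7.6-fold lower number from compound 1 to compound 2 (0.88 log units; beyond the scatter), and its size can only be given as a bound, since it rests on (the limit of > 100000 nM in this assay, at which 1 of the 2 values shown sits).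

Compound 3 is `CCCN1CCN(c2ccc(S(=O)(=O)Oc3ccc(OC)cc3)cc2)C1=O`. It differs from compound 2 as follows: 4-methoxyphenyl in place of 2,4,5-trichlorophenyl on an oxygen. This step reverses the direction of the measured one, swapping the 2,4,5-trichlorophenyl back for a small single-substituent phenyl of the kind carried by compound 1. The number for compound 3 is therefore expected to rise, quite possibly back toward a limit. The expected change is a 4.6-fold higher number from compound 2 to compound 3 (0.66 log units; beyond the scatter). Compound 3 is estimated at 60000 nM, within a range of 20000 nM to 200000 nM.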

Compound 3, half-maximal inhibitory concentration: 20000 nM
Beside the measured number, compound 3's estimate is 3.0-fold (0.48 log units) above it; the measured number falls inside the stated range.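

In this assay, the three chlorines of the 2,4,5-trichlorophenyl group prove unnecessary at this position, on the oxygen bonded to the sulfonyl sulfur: a 1.5-fold higher number from compound 2 to compound 3 (0.19 log units; within the scatter), so 4-methoxyphenyl and 2,4,5-trichlorophenyl cannot be told apart here. A ring without chlorine can therefore still give a measurable number, and the choice of single-substituent phenyl matters: an at least 5.0-fold lower number from compound 1 to compound 3 (0.69 log units; beyond the scatter). Compound 1 carries a limit of the assay, not a number, so this step is only a bound: the limit of > 100000 nM in this assay, at which 1 of the 3 values shown sits.

Since 2-methylphenyl and 4-methoxyphenyl differ in both the group and its place on the ring, these compounds cannot show which of the two matters. Going by these compounds, it also remains open how a plain phenyl, or a phenyl carrying an amine or a carboxylic acid, would fare at this position.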